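The source may report more compounds than this note shows. Statements on the series, on what has been measured and on what is new or still open speak of the compounds shown alone.

Measured compounds:
Compound 1, `Cc1cc(=O)n(-c2cccc(F)c2)nc1C(=O)Nc1ccc(Oc2ncnc3[nH]ccc23)cc1`: 3180 nM
Compound 2, `Cc1cc(=O)n(-c2cccc(F)c2)nc1C(=O)Nc1ccc(Oc2ncnc3[nH]ccc23)c(F)c1`: 23100 nM
Compound 3, `Cc1cc(=O)n(-c2ccc(Br)cc2F)nc1C(=O)Nc1ccc(Oc2ncnc3[nH]ccc23)c(F)c1`: 32000 nM

In a functional assay on HepG2 cells (Homo sapiens) for cytotoxicity, read by MTT assay, with a stated time of 72 h (a higher number here means a weaker inhibitor, a lower number a stronger inhibitor), compound 2 gives 23100 nM, the second highest of the three numbers. Its nearest neighbour is compound 3, and the step of a 1.4-fold higher number from compound 2 to compound 3 (0.14 log units; within the scatter) lies within the scatter, so the two cannot be ordered. Its furthest neighbour is compound 1, and the step of a 7.3-fold higher number from compound 1 to compound 2 (0.86 log units; beyond the scatter) is beyond the scatter.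

Compound 4, `Cc1cc(=O)n(-c2cccc(F)c2)nc1C(=O)Nc1ccc(Oc2ncnc3c2ccn3C)c(F)c1`, differs from compound 2 in one place: methyl in place of hydrogen on an aromatic nitrogen. Neither measured step touches this position. The step of a 7.3-fold higher number from compound 1 to compound 2 (0.86 log units; beyond the scatter) concerns a fluoro on an aromatic carbon of a different ring, and the step of a 1.4-fold higher number from compound 2 to compound 3 (0.14 log units; within the scatter) concerns an aryl group on a different aromatic nitrogen; the methyl of compound 4 sits on the five-membered ring of the fused system, for which no comparison exists among the measured compounds. With nothing to anchor a direction, compound 4 is expected to stay close to compound 2, a step of a 1.0-fold lower number from compound 2 to compound 4 (0.00 log units; within the scatter) that is not expected to go beyond the scatter. Compound 4 is therefore estimated at 23000 nM in this assay, with a range from 8000 nM to 70000 nM.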

Compound 4, half-maximal inhibitory concentration: > 60000 nM
Compound 4 ended at the assay's limit (the forecaster's own chance of this, stated with the estimate: 15%); middle value at least 2.6-fold (0.41 log units) from the limit.
By their numbers in this assay, from the lowest: compound 1; then compounds 2 and 3 (each within the scatter of the next). At a limit, above all of these: compound 4.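

Within the data shown here, the nitrogen of the five-membered aromatic ring had not been varied among the earlier compounds, and compound 4 gives the first reading of it in this assay: methyl in place of hydrogen on this aromatic nitrogen gives an at least 2.5-fold higher number from compound 2 to compound 4 (0.41 log units; beyond the scatter). A change of one heavy atom at this position therefore goes beyond the scatter, whereas the much larger change of aryl group on the other aromatic nitrogen, a 1.4-fold higher number from compound 2 to compound 3 (0.14 log units; within the scatter), stays within it. The figure for compound 4 is a limit of the assay and not a number, so the step gives a direction and a lowest size, while its full size stays unknown: the limit of > 60000 nM in this assay, at which 1 of the 4 values shown sits.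

Going by these compounds, whether an ethyl group, a longer chain or a chain carrying an amine on this nitrogen would give the same result as the methyl stays open, as does whether the methyl would give a similar step on the core of compound 1, which lacks the fluoro of compound 2. On these data alone, what the step rests on also stays unknown: only hydrogen and methyl appear at this nitrogen.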